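Swapping an amide-bearing side chain back to an aryl amidine

A few compounds are considered here, and "the series" means these few. Any claim that something is new, unique, unknown or untested is made for them only; others in the source may bear on it.

Of the compounds shown here, two of a shared core have been tested in a functional assay on the whole organism (strain albino) for inhibition, with Rattus norvegicus as the target, read by paw edema, with a stated time of 1 h, at a dose of 20 mmol/kg by the intraperitoneal route; on this read-out higher numbers stand for more inhibition at the one dose given (going by the name of the read-out) and lower numbers for less inhibition. Compound 1 `N#CC1=C(/N=C/Nc2ccc([N+](=O)[O-])cc2)N(c2ccccc2)C(=O)N2CCCCC(N3CCCC3)C12` gives 32.1%, and compound 2 `N#CC1=C(NCC(=O)N2CCCC2)N(c2ccccc2)C(=O)N2CCCCC(N3CCCC3)C12` gives 40.1%. On the numbers alone compound 2 sits on top, but the step of a number 8 percentage points higher from compound 1 to compound 2 (within the scatter) is within the scatter, so the two cannot be told apart. Within the data shown here, compound 3 `COc1ccc(N/C=N/C2=C(C#N)C3C(N4CCCC4)CCCCN3C(=O)N2c2ccccc2)cc1` differs from compound 2 in this way: a group of 11 heavy atoms (8 carbon, 2 nitrogen, 1 oxygen; one six-membered aromatic ring of carbon only) in place of a group of 9 heavy atoms (6 carbon, 2 nitrogen, 1 oxygen; one five-membered non-aromatic ring with 1 hetero atom), on a double-bonded ring carbon The only measured step that bears on such a change is a number 8 percentage points higher from compound 1 to compound 2 (within the scatter), which stayed within the scatter, so no shift beyond the scatter is expected in this assay. Compound 3 is therefore estimated at 35%, with a range from 24% to 46%. That means a step of a number 5.1 percentage points lower from compound 2 to compound 3 (within the scatter) is expected.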

Compound 3, a percentage reported as inhibition, in the whole organism at one dose (the size of the read-out at that dose, not a potency): 20.6%
For compound 3 the middle estimate is 14.4 percentage points above the measured one, outside the stated range (below it).
By their numbers in this assay, from the lowest: compound 3; then compounds 1 and 2 (each within the scatter of the next).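

In this assay this position does respond to the change: the aryl amidine with methoxy in place of the (((pyrrolidin-1-yl)carbonyl)methyl)amino group gives a number 19.5 percentage points lower from compound 2 to compound 3 (beyond the scatter). Among the two aryl amidines, methoxy in place of nitro on an aromatic carbon gives a number 11.5 percentage points lower from compound 1 to compound 3 (beyond the scatter), so the group on that aromatic ring matters as well, which compound 1 and compound 2 alone could not show.

From the compounds shown here alone, whether a chloro group or an amine on that ring would read closer to compound 1 or to compound 3 stays open. No measurement at hand says why these numbers move.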